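The source may report more compounds than this note shows. Statements on the series, on what has been measured and on what is new or still open speak of the compounds shown alone.

Measured so far in a functional assay on SMMC-7721 cells (Homo sapiens) for antiproliferative activity, read by MTT assay, with a stated time of 48 h; a lower number here means a stronger inhibitor, a higher number a weaker inhibitor:
- compound 1 `CC(=O)OC/C1=C/C[C@](C)(CCC=C(C)C)/C=C/[C@@H](OC(=O)C=C(C)C)[C@](C)(OC(C)=O)/C=C/C1=O`: 4130 nM
- compound 2 `CC(C)=CCC[C@]1(C)/C=C/[C@@H](OC(=O)C=C(C)C)[C@](C)(O)/C=C/C(=O)/C(CN(C)C)=C\C1`: 820 nM
- compound 3 `CC(C)=CCC[C@]1(C)/C=C/[C@@H](OC(=O)C=C(C)C)[C@](C)(O)/C=C/C(=O)/C(CN2CCCC2)=C\C1`: 140 nM

Compound 3 has the lowest number of the three at 140 nM, which makes it the strongest inhibitor so far. The next compound, compound 4 `CC(C)=CCC[C@]1(C)/C=C/[C@@H](OC(=O)C=C(C)C)[C@](C)(O)/C=C/C(=O)/C(CN=[N+]=[N-])=C\C1`, changes a single group of compound 3: azido in place of pyrrolidin-1-yl on a saturated chain carbon bound to a double-bonded ring carbon.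

For the measured compounds named here, only one measured step touches this place: a 5.9-fold lower number from compound 2 to compound 3 (0.77 log units; beyond the scatter). That modest step, with pyrrolidin-1-yl replacing dimethylamino, shows that the number in this assay can shift with the group held here. Azido itself has not been measured, so this step offers a rough size but no firm direction. Since compound 3 already sits lowest, a higher number, meaning a weaker inhibitor, seems the likelier outcome. The expected change is an 8.6-fold higher number from compound 3 to compound 4 (0.93 log units; beyond the scatter), similar to or somewhat larger than the measured step. For compound 4 the estimated value is 1200 nM, with an expected range from 250 nM to 5000 nM.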

Compound 4, half-maximal inhibitory concentration: 3080 nM
Estimate against measurement, compound 4: 2.6-fold (0.41 log units) below, and the stated range covers the measured number.
By their numbers in this assay, from the lowest: compound 3; then compound 2; then compounds 4 and 1 (each within the scatter of the next).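

In this assay, for the compounds shown here, this is the first measured group on the saturated chain carbon bound to a double-bonded ring carbon that has no carbon attached to its nitrogen, and the number rises whichever amine it replaces: azido for pyrrolidin-1-yl is a large step (a 22-fold higher number from compound 3 to compound 4 (1.34 log units; beyond the scatter)), while azido for dimethylamino is a modest one (a 3.8-fold higher number from compound 2 to compound 4 (0.57 log units; beyond the scatter)). Among the three groups measured at this place, pyrrolidin-1-yl therefore gives the lowest number and azido the highest, so the earlier gain now has a direction against a group that is not an amine. No measurement shown here explains why azido behaves this way.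

As far as these compounds go, whether a piperidin-1-yl or morpholin-4-yl group would go lower than the pyrrolidin-1-yl of compound 3 remains open. So does the effect of a simple primary amine or a carboxylic acid at this place.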